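The source may report more compounds than this note shows. Statements on the series, on what has been measured and on what is new or still open speak of the compounds shown alone.

Measured in a functional assay on HeLa cells (Homo sapiens) for antiproliferative activity, read by MTT assay, with a stated time of 72 h; a lower number here means a stronger inhibitor, a higher number a weaker inhibitor:
compound 1 `CCn1cc(C(=O)O)c(=O)c2cc(F)c(N3CCN(C(=N)NS(=O)(=O)c4ccc(C(F)(F)F)cc4)CC3)cc21`: 32 nM
compound 2 `CCn1cc(C(=O)O)c(=O)c2cc(F)c(N3CCN(C(=N)NS(=O)(=O)c4ccccc4C(F)(F)F)CC3)cc21`: 32 nM

Among the compounds with values here, compound 2 stands level with compound 1, its only measured neighbour. Compound 3 `CCn1cc(C(=O)O)c(=O)c2cc(F)c(N3CCN(C(=N)NS(=O)(=O)c4ccc(C)cc4)CC3)cc21` carries 4-methylphenyl in place of 2-(trifluoromethyl)phenyl on a sulfonyl sulfur. Within the data shown here, the one measured step that bears on this change is no change at the digits printed from compound 1 to compound 2 (within the scatter), which exchanged 4-(trifluoromethyl)phenyl for 2-(trifluoromethyl)phenyl and stayed within the scatter. Among the measured compounds shown here, no measured step exchanges trifluoromethyl for methyl, so this support is indirect. No step beyond the scatter is therefore expected in this assay. The estimated step is a 1.3-fold higher number from compound 2 to compound 3 (0.10 log units; within the scatter). For compound 3 the expected value is 40 nM, within an estimated range of 15 nM to 110 nM.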

Compound 3, half-maximal inhibitory concentration: 32 nM
The estimate for compound 3 lay 1.3-fold (0.10 log units) above the measured number; the range from low to high includes it.
By their numbers in this assay, from the lowest: compounds 1, 2 and 3 (each within the scatter of the next).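

In this assay, within the data shown here, replacing trifluoromethyl with methyl on an aromatic carbon gave the first direct comparison of these two groups (no change at the digits printed from compound 1 to compound 3 (within the scatter)). The exchange of 2-(trifluoromethyl)phenyl for 4-methylphenyl on the sulfonyl sulfur also stayed within the scatter (no change at the digits printed from compound 2 to compound 3 (within the scatter)), so fluorine is not needed on this aryl group to hold the level seen here. No available evidence accounts for this result. On these data alone, it remains open whether an amine, a methoxy group or a longer alkyl chain on the ring would hold this level, or whether an unsubstituted phenyl would.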